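Adding Chloro to Compound 3: Cytotoxicity Expectation

The source may report more compounds than this note shows. Statements on the series, on what has been measured and on what is new or still open speak of the compounds shown alone.

The series shares one core, seen in compound 1 `Fc1cccc(F)c1Cc1cnc(Nc2ccc(Oc3ccncc3)c(Cl)c2)o1`, compound 2 `[O-][n+]1ccc(OCc2ccc(Nc3ncc(Cc4c(F)cccc4F)o3)cc2Cl)cc1` and compound 3 `Fc1cccc(F)c1Cc1cnc(Nc2ccc(COc3ccncc3)cc2)o1`. In an ADME assay on MT2 cells (Homo sapiens) for cytotoxicity, read by MTT assay (a higher number here means that more compound is tolerated, a lower number that less compound is tolerated), compound 1 gives 21000 nM, and compound 2 gives 1700 nM. Compound 3 is reported only as a limit of this assay, > 100000 nM, so it sits at the limit of > 100000 nM in this assay, at which 1 of the 3 values shown sits, rather than at a number.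

Compound 4 `Fc1cccc(F)c1Cc1cnc(Nc2ccc(COc3ccncc3)c(Cl)c2)o1` is not yet measured. It differs from compound 3 in one place: chloro in place of hydrogen on an aromatic carbon. Going by the values given here, no measured step covers this change. Among the compounds with values here, the only measured step, a 12-fold lower number from compound 1 to compound 2 (1.09 log units; beyond the scatter), concerns a different group and says nothing direct about chloro in place of hydrogen. What remains is that compound 1 carries chloro and gives 21000 nM in this assay, a number well inside the measurable range.

Compound 4 is therefore expected to fall below the limit, estimated at 40000 nM with a range of 12000 nM to 150000 nM. The expected step of an at least 2.5-fold lower number from compound 3 to compound 4 (0.39 log units; beyond the scatter) is uncertain in size, since compound 3 has only a limit.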

Compound 4, half-maximal cytotoxic concentration: 3800 nM
Beside the measured number, compound 4's estimate is 11-fold (1.02 log units) above it; the measured number lies below the stated range.
By their numbers in this assay, from the lowest: compound 2; then compound 4; then compound 1. At a limit, above all of these: compound 3.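

Chloro in place of hydrogen on this aromatic carbon, ortho to the ((pyridin-4-yl)oxy)methyl group, now has its own measured step in this assay (an at least 26-fold lower number from compound 3 to compound 4 (1.42 log units; beyond the scatter)), and that step is large. Compound 3 stands at a limit, so the step has a floor and no upper end: the limit of > 100000 nM in this assay, at which 1 of the 4 values shown sits. With chloro kept, the two other changes give modest steps (a 5.5-fold lower number from compound 1 to compound 4 (0.74 log units; beyond the scatter); a 2.2-fold higher number from compound 2 to compound 4 (0.35 log units; beyond the scatter)), and among the compounds shown, all three carrying chloro have numbers, while compound 3, without it, has only a limit.

From the compounds shown here alone, the true size of the chloro step stays open. So does whether fluoro, methyl or an amine on the same carbon would lower the number as far as chloro does.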